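One More Chain Carbon on Two Different Cores

This account rests on a few compounds, and the source may have more. Where it says the series, first, only, none or still open, it means among the compounds named here.

Compound 1 `COc1cc2c(Nc3ccc(OCc4cccc(F)c4)c(Cl)c3)ncnc2cc1OCCCCCn1ccnc1[N+](=O)[O-]` and compound 2 `COc1cc2c(Nc3ccc(OCc4cccc(F)c4)c(Cl)c3)ncnc2cc1OCCCCCCn1ccnc1[N+](=O)[O-]` share a core and differ only in the length of the chain carrying the nitroimidazole. In a functional assay on A549 cells (Homo sapiens) for inhibition, read by sulforhodamine B assay, with a stated time of 72 h (a higher number here means a weaker inhibitor, a lower number a stronger inhibitor), compound 1 gives 19900 nM. For compound 2 the same assay reports only a limit, > 50000 nM. The change is (2-nitro-1H-imidazol-1-yl)methyl in place of 2-nitro-1H-imidazol-1-yl on a saturated chain carbon, five bonds along the chain from an oxygen on an aromatic ring, and the step is an at least 2.5-fold higher number from compound 1 to compound 2 (0.40 log units; beyond the scatter); its size is bounded by the limit of > 50000 nM in this assay, at which 1 of the 3 values shown sits.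

Compound 3 `COc1cc2c(Nc3cccc(Br)c3)ncnc2cc1OCCCn1ccnc1[N+](=O)[O-]` carries a different core, and the difference between the two cores is not broken down here. In this assay compound 3 gives 13500 nM. Compound 4 `COc1cc2c(Nc3cccc(Br)c3)ncnc2cc1OCCCCn1ccnc1[N+](=O)[O-]` is derived from compound 3 by (2-nitro-1H-imidazol-1-yl)methyl in place of 2-nitro-1H-imidazol-1-yl on a saturated chain carbon, three bonds along the chain from an oxygen on an aromatic ring. This is the same kind of change as in the measured pair, though the place differs: three bonds along the chain from the aromatic oxygen here, against five bonds there.

On the measured step of an at least 2.5-fold higher number from compound 1 to compound 2 (0.40 log units; beyond the scatter), the step to compound 4 is expected to be a 2.1-fold higher number from compound 3 to compound 4 (0.32 log units; beyond the scatter). The estimate for compound 4 in this assay is 28000 nM, with a range from 11000 nM to 70000 nM.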

Compound 4, half-maximal inhibitory concentration: 3090 nM
Compound 4: middle estimate off by 9.1-fold (0.96 log units), on the high side; the measured number lies below the stated range.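

In this assay the same change that had weakened the earlier pair went the other way on the core of compound 3, with a 4.4-fold lower number from compound 3 to compound 4 (0.64 log units; beyond the scatter) as the new step. The direction of this change therefore did not carry from one core to the other in these two pairs, and the two steps stand clearly apart: the same change on two cores in this assay, an at least 2.5-fold higher number (0.40 log units; beyond the scatter) from compound 1 to compound 2 and a 4.4-fold lower number (0.64 log units; beyond the scatter) from compound 3 to compound 4, at least 10-fold (1.04 log units) apart, beyond the scatter of two such steps. The comparison does not show whether the core or the place of the change decides the outcome, three bonds along the chain from the aromatic oxygen here against five bonds there, and the earlier step has no exact size, resting on a value that is only a limit: the limit of > 50000 nM in this assay, at which 1 of the 4 values shown sits.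

The compounds shown leave open how a shorter chain behaves on the core of compound 1, and how a longer chain behaves on the core of compound 3. They also leave open whether either trend would hold if an amine took the place of the 2-nitro-1H-imidazol-1-yl group at the chain end.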